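Hydroxy to chloro on the aryl of compound 2

This account rests on a few compounds, and the source may have more. Where it says the series, first, only, none or still open, it means among the compounds named here.

Three compounds share the core of compound 1 `COc1ccc(/C=N/c2c(C)n(C)n(-c3ccccc3)c2=O)cc1` and differ only in the aryl on the carbon with a double bond to nitrogen. In a functional assay on HCT-116 cells (Homo sapiens) for cytotoxicity, read by MTT assay, with a stated time of 72 h (on this read-out lower numbers stand for stronger inhibition and higher numbers for weaker inhibition), compound 1 gives 575000000 nM. Compound 2 `Cc1c(/N=C/c2cccc(O)c2)c(=O)n(-c2ccccc2)n1C` gives 617000000 nM in this assay, and compound 3 `COc1ccccc1/C=N/c1c(C)n(C)n(-c2ccccc2)c1=O` gives 324000000 nM. The three steps, a 1.1-fold higher number from compound 1 to compound 2 (0.03 log units; within the scatter), a 1.8-fold lower number from compound 1 to compound 3 (0.25 log units; within the scatter) and a 1.9-fold lower number from compound 2 to compound 3 (0.28 log units; within the scatter), all lie within the scatter, so compound 2 stands level with the other two on the numbers shown.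

Compound 4 `Cc1c(/N=C/c2cccc(Cl)c2)c(=O)n(-c2ccccc2)n1C` differs from compound 2 by chloro in place of hydroxy on an aromatic carbon, that is 3-hydroxyphenyl to 3-chlorophenyl, meta to a large group. Within the data shown here, no measured step swaps hydroxy for chloro; the measured steps only move or exchange oxygen-bearing groups on the aryl, and none of them moves the number beyond the scatter. With the whole series flat, the expected step of a 1.2-fold lower number from compound 2 to compound 4 (0.09 log units; within the scatter) is none beyond the scatter. Compound 4 is therefore estimated at 500000000 nM in this assay, with a range from 200000000 nM to 1500000000 nM.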

Compound 4, half-maximal inhibitory concentration: 912000000 nM
Compound 4: middle estimate off by 1.8-fold (0.26 log units), on the low side, within the range that was stated.
By their numbers in this assay, from the lowest: compounds 3, 1, 2 and 4 (each within the scatter of the next, the first and the last beyond it).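

In this assay chloro in place of hydroxy on this aromatic carbon (a 1.5-fold higher number from compound 2 to compound 4 (0.17 log units; within the scatter)) leaves compound 4 level with compound 2, so this position tolerates the loss of the oxygen and its hydrogen-bond donor without a step beyond the scatter. Among these compounds, compound 4 also stays level with the 4-methoxyphenyl of compound 1 (a 1.6-fold higher number from compound 1 to compound 4 (0.20 log units; within the scatter)), but its gap to the 2-methoxyphenyl of compound 3 (a 2.8-fold higher number from compound 3 to compound 4 (0.45 log units; beyond the scatter)) is the only modest step beyond the scatter. No measurement shown accounts for that gap.

The gap to compound 3 changes the group and its place together, so the contribution of each stays unresolved. From the compounds shown here alone, whether an amine, a carboxylic acid or a longer chain on this aryl would move the number further remains open.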